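Adding a Fluoro Group to Compound 2: Expected Outcome

The compounds below may be only part of what the source reports. "The series", "measured", "known", "first", "only" and "open" are said of these compounds alone.

compound 1 `COc1ccc(-c2ccnc(C(=O)Nc3ccc(Oc4ccnc5[nH]ccc45)cc3)c2)cc1`: 6970 nM
compound 2 `O=C(Nc1ccc(Oc2ccnc3[nH]ccc23)cc1)c1cc(-c2ccc(C(F)(F)F)cc2)ccn1`: 3950 nM
compound 3 `O=C(Nc1ccc(Oc2ccnc3[nH]ccc23)cc1)c1cc(-c2ccc(Cl)cc2)ccn1`: 4310 nM

In a functional assay on A549 cells (Homo sapiens) for cytotoxicity, read by MTT assay, with a stated time of 72 h (a lower number here means a stronger inhibitor, a higher number a weaker inhibitor), compound 2 gives the lowest of the three numbers, but the step of a 1.1-fold higher number from compound 2 to compound 3 (0.04 log units; within the scatter) and the step of a 1.8-fold lower number from compound 1 to compound 2 (0.25 log units; within the scatter) both lie within the scatter, so no order among the three compounds can be claimed. Compound 4 `O=C(Nc1ccc(Oc2ccnc3[nH]ccc23)c(F)c1)c1cc(-c2ccc(C(F)(F)F)cc2)ccn1` differs from compound 2 by fluoro in place of hydrogen on an aromatic carbon. Among the compounds with values here, none of the measured steps touches this change: the steps of a 1.8-fold lower number from compound 1 to compound 2 (0.25 log units; within the scatter), a 1.6-fold lower number from compound 1 to compound 3 (0.21 log units; within the scatter) and a 1.1-fold higher number from compound 2 to compound 3 (0.04 log units; within the scatter) all exchange one group for another elsewhere in the molecule, and all stay within the scatter. The data therefore give no reason to expect a step beyond the scatter in this assay in either direction. Compound 4 is estimated at 3500 nM, with a range from 1500 nM to 9000 nM, which is expected to mean a step of a 1.1-fold lower number from compound 2 to compound 4 (0.05 log units; within the scatter).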

Compound 4, half-maximal inhibitory concentration: 4920 nM
For compound 4 the middle estimate is 1.4-fold (0.15 log units) below the measured one; measured number inside the range.
By their numbers in this assay, from the lowest: compounds 2, 3, 4 and 1 (each within the scatter of the next).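

In this assay, fluoro in place of hydrogen on an aromatic carbon, ortho to a large group and meta to a large group, gives a 1.2-fold higher number from compound 2 to compound 4 (0.10 log units; within the scatter). This is the first change shown on this ring, and like the earlier exchanges elsewhere in the molecule, it stays within the scatter, so this small substitution at this position is tolerated. Nothing available bears on the reason for this result.

From the compounds shown here alone, whether an amine or a carboxylic acid on this same carbon would give a step beyond the scatter remains open. Also open, going by these compounds, is whether fluoro here would give a similar step with chloro or methoxy in place of trifluoromethyl.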